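The compounds below may be only part of what the source reports. "The series", "measured", "known", "first", "only" and "open" are said of these compounds alone.

Working notes on the series. Compound 1 `CCC(C)(C)Cc1c[nH]c(CCc2ccc(-c3cccc(C)n3)cc2)n1` gives 102 nM in a functional assay on HEK293 cells for agonist activity at Bombesin receptor subtype-3 (Homo sapiens), read by luminescence and calcium flux, with a stated time of 10 min; a higher number here means that more compound is needed for the effect, a lower number that less compound is needed. Compound 2 `CCC(C)(C)Cc1c[nH]c(CCc2ccc(-c3ccncc3)cc2)n1` gives 95 nM in this assay, and compound 3 `CCC(C)(C)Cc1c[nH]c(CCc2ccc(N3CCCCC3)cc2)n1` gives 108 nM in this assay. Compound 3 carries the highest number of the three, but the three numbers sit together: a 1.1-fold lower number from compound 1 to compound 2 (0.03 log units; within the scatter), a 1.1-fold higher number from compound 1 to compound 3 (0.02 log units; within the scatter) and a 1.1-fold higher number from compound 2 to compound 3 (0.06 log units; within the scatter) all fall within the scatter, so nothing separates these compounds on this read-out.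

The next compound, compound 4 `CCC(C)(C)Cc1c[nH]c(CCc2ccc(-c3cccnc3C(=O)O)cc2)n1`, differs from compound 3 by 2-carboxypyridin-3-yl in place of piperidin-1-yl on an aromatic carbon. Within the data shown here, all three measured steps exchange the group on the aromatic carbon para to a large group, and all three stayed within the scatter; none of them brings in a carboxylic acid, so no measured step speaks directly to the entering group. Among the measured compounds shown here, on the measured steps alone, the expected step from compound 3 to compound 4 is a 1.4-fold higher number from compound 3 to compound 4 (0.14 log units; within the scatter), a small change, with a wide range because the acid has no precedent among compounds 1 to 3. Compound 4 is therefore expected to give about 150 nM in this assay, within 50 nM to 500 nM.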

Compound 4, half-maximal effective concentration: 95 nM
The estimate for compound 4 lay 1.6-fold (0.20 log units) above the measured number; low and high end bracket the measured number.
By their numbers in this assay, from the lowest: compounds 2, 4, 1 and 3 (each within the scatter of the next).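

Placing 2-carboxypyridin-3-yl on the aromatic carbon para to a large group extends the flat picture to a carboxylic acid in this assay, with a 1.1-fold lower number from compound 3 to compound 4 (0.06 log units; within the scatter) and no change at the digits printed from compound 2 to compound 4 (within the scatter) and a 1.1-fold lower number from compound 1 to compound 4 (0.03 log units; within the scatter) as the three readings. The position therefore accepts this acid-bearing ring as readily as it accepts the piperidin-1-yl, pyridin-4-yl and 6-methylpyridin-2-yl groups, and no exchange shown at this position separates any of the four compounds. No measurement offered here accounts for this insensitivity.

The compounds shown leave open whether an ester, a primary amide or an aminomethyl group at this position would also stay within the scatter. They also leave open whether any group at this position can shift the number, since all four compounds sit together.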